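Sulfonamide series: aryl swap on the amine arm

A few compounds are considered here, and "the series" means these few. Any claim that something is new, unique, unknown or untested is made for them only; others in the source may bear on it.

Three members of the series have numbers in a functional assay on MCF7 cells (Homo sapiens) for inhibition, read by MTT assay, with a stated time of 72 h; on this read-out higher numbers stand for weaker inhibition of growth and lower numbers for stronger inhibition of growth. Compound 1 `O=S(=O)(NCCNCc1cccc2ccccc12)c1cc(C(F)(F)F)cc(C(F)(F)F)c1` gives 18000 nM. Compound 3 `O=S(=O)(NCCNCc1ccc(-c2ccccc2)cc1)c1cc(C(F)(F)F)cc(C(F)(F)F)c1` gives 1400 nM. Compound 2 `CC(C)(C)c1ccc(CNCCCNS(=O)(=O)c2cc(C(F)(F)F)cc(C(F)(F)F)c2)cc1` gives 2100 nM, the second highest of the three numbers; compound 3 sits within the scatter of it, while compound 1 lies well beyond the scatter on the weaker side. Compound 4 `O=S(=O)(NCCCNCc1ccc(Cl)c(C(F)(F)F)c1)c1cc(C(F)(F)F)cc(C(F)(F)F)c1` is not yet measured and differs from compound 2 by 4-chloro-3-(trifluoromethyl)phenyl in place of 4-(tert-butyl)phenyl on a saturated chain carbon bound to an amine nitrogen. Within the data shown here, no measured pair carries this change, so no step size can be read from the data. Compound 4 is expected to show a step of a 1.2-fold higher number from compound 2 to compound 4 (0.08 log units; within the scatter) that stays within the scatter. Compound 4 is estimated in this assay at 2500 nM, with a range from 800 nM to 8000 nM.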

Compound 4, concentration for 50% growth inhibition: 3500 nM
Compound 4: the middle estimate sits 1.4-fold (0.15 log units) below what was measured; the measured number falls inside the stated range.
By their numbers in this assay, from the lowest: compounds 3, 2 and 4 (each within the scatter of the next, the first and the last beyond it); then compound 1.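

At the saturated chain carbon bound to an amine nitrogen, 4-chloro-3-(trifluoromethyl)phenyl in place of 4-(tert-butyl)phenyl gives a 1.7-fold higher number from compound 2 to compound 4 (0.22 log units; within the scatter) in this assay. Among these compounds, this is the first readable step, and on this read-out the two aryl groups cannot be told apart. No measured evidence bears on this result.

Compounds 1 and 3 differ from compound 2 in more than one place, so the effects of the aryl group and the chain remain unseparated. From the compounds shown here alone, how a pyridine ring or a carboxylic acid-bearing phenyl would fare at this place remains open.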